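A few compounds are considered here, and "the series" means these few. Any claim that something is new, unique, unknown or untested is made for them only; others in the source may bear on it.

Measured so far:
compound 1 `CCCn1c(=O)[nH]c2nc(-c3ccc(S(=O)(=O)N4CCN(c5ccc(F)cc5)CC4)cc3)[nH]c2c1=O`: 0.644 nM
compound 2 `CCCn1c(=O)[nH]c2nc(-c3ccc(S(=O)(=O)N4CCN(c5ccc(Cl)cc5F)CC4)cc3)[nH]c2c1=O`: 1.91 nM

In an assay on CHO cells for displacement of a labelled ligand from adenosine receptor A2b (Homo sapiens), read by scintillation counting, with a stated time of 75 min, in the presence of a further agent that is not named here (on this read-out higher numbers stand for weaker inhibition and lower numbers for stronger inhibition), compound 1 gives 0.644 nM, the lowest of the two numbers; compound 2 gives 1.91 nM. Compound 3 `CCCn1c(=O)[nH]c2nc(-c3ccc(S(=O)(=O)N4CCN(Cc5cccc(Br)c5)CC4)cc3)[nH]c2c1=O` is not yet measured and differs from compound 1 as follows: 3-bromobenzyl in place of 4-fluorophenyl on an amine nitrogen in a ring. Going by the values given here, the one measured step at the same amine nitrogen in a ring is a 3.0-fold higher number from compound 1 to compound 2 (0.47 log units; beyond the scatter), a modest rise beyond the scatter. A change at that place with 3-bromobenzyl rather than an aryl group is expected to give a rise of similar modest size, with a wide range since no benzyl has been measured. Compound 3 is expected to give 2.5 nM, between 0.6 nM and 10 nM, an estimated step of a 3.9-fold higher number from compound 1 to compound 3 (0.59 log units; beyond the scatter).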

Compound 3, inhibition constant: 0.148 nM
For compound 3 the middle estimate is 17-fold (1.23 log units) above the measured one; the measured number lies below the stated range.
By their numbers in this assay, from the lowest: compound 3; then compound 1; then compound 2.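

With 3-bromobenzyl on the amine nitrogen in a ring, this assay shows a 4.4-fold lower number from compound 1 to compound 3 (0.64 log units; beyond the scatter) and also a 13-fold lower number from compound 2 to compound 3 (1.11 log units; beyond the scatter), so this place can move the number downward as well as upward. The ring nitrogen therefore accepts a benzyl group as well as the aryl groups of compound 1 and compound 2, and compound 3 has the lowest number of the three. No evidence here accounts for this shift.

The compounds shown do not separate the contribution of the benzyl carbon from that of the bromine. Unsubstituted benzyl, 4-bromobenzyl and a longer chain such as phenethyl remain open.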